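Sulfonyl aryl swaps in a cytotoxicity-silent series

This account rests on a few compounds, and the source may have more. Where it says the series, first, only, none or still open, it means among the compounds named here.

The compounds share one core and differ only in the group on the sulfonyl sulfur: compound 1 `CC1CCN(C2CCN(S(=O)(=O)c3ccc(C#N)cc3)CC2)CC1` carries a 4-cyanophenyl, compound 2 `CC1CCN(C2CCN(S(=O)(=O)c3ccc(Cl)c(Cl)c3)CC2)CC1` a 3,4-dichlorophenyl, compound 3 `CC1CCN(C2CCN(S(=O)(=O)c3cncc(Br)c3)CC2)CC1` a 5-bromopyridin-3-yl. In an ADME assay on HCT-116 cells (Homo sapiens) for cytotoxicity, read by CellTiter-Glo, with a stated time of 72 h (a lower number here means a stronger inhibitor, a higher number a weaker inhibitor), compound 1 gives > 5000 nM, a limit of the assay. Compound 2 gives > 5000 nM in this assay, again a limit. Compound 3 gives > 10000 nM in this assay, also a limit. The steps a step that the two limits leave unreadable from compound 1 to compound 2, a step that the two limits leave unreadable from compound 1 to compound 3 and a step that the two limits leave unreadable from compound 2 to compound 3 therefore cannot be sized; the evidence is the limit of > 5000 nM in this assay, at which 2 of the 3 values shown sit, and (the limit of > 10000 nM in this assay, at which 1 of the 3 values shown sits). Compound 4 `CC1CCN(C2CCN(S(=O)(=O)c3ccc(Cl)nc3)CC2)CC1` changes compound 3 by 6-chloropyridin-3-yl in place of 5-bromopyridin-3-yl on a sulfonyl sulfur. With only unreadable steps bearing on it, the expected step of a number no higher from compound 3 to compound 4 (the limit leaves the size open) is none beyond the scatter. Compound 4 is expected to give 10000 nM in this assay, estimated between 3000 nM and 30000 nM, most likely reported again as a limit.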

Compound 4, half-maximal inhibitory concentration: > 10000 nM
Compound 4 was reported as a limit (the forecaster's own chance of this, stated with the estimate: 85%); the middle value sits exactly at the limit.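

Among the compounds shown here, compound 4 gives [ > 10000 nM ] in this assay, again a limit, and no step linking it to compound 1, compound 2 or compound 3 can be read. On these data alone, whether these four sulfonyl groups differ at all in this assay stays open.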